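The source may report more compounds than this note shows. Statements on the series, on what has been measured and on what is new or still open speak of the compounds shown alone.

Measured so far in an ADME assay on HEK293 cells (Homo sapiens) for cytotoxicity, read by CellTiter-Glo and resazurin assay, with a stated time of 72 h; on this read-out higher numbers stand for an effect only at larger amounts of compound and lower numbers for an effect already at smaller amounts:
compound 1, `COc1cccc(-c2ccc(C(=O)N(Cc3cccc(OCCCCCC(=O)O)c3)C(C)C)cc2)c1`, gives > 20900 nM, a limit of the assay.
compound 2, `CCOC(=O)CCCCCOc1cccc(CN(C(=O)c2ccc(-c3cccc(OC)c3)cc2)C(C)C)c1`, gives > 21000 nM, also a limit of the assay.

Going by the values given here, compound 2 thus stands only at a limit on this read-out, as does the one other value shown (the limit of > 21000 nM in this assay, at which 1 of the 2 values shown sits, (the limit of > 20900 nM in this assay, at which 1 of the 2 values shown sits)). The step that the two limits leave unreadable from compound 1 to compound 2 stays unreadable between the two limits.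

Compound 3, `CCOC(=O)CCCCCOc1cccc(CN(C(=O)c2ccc(Br)cc2)C(C)C)c1`, differs from compound 2 by bromo in place of 3-methoxyphenyl on an aromatic carbon. No measured step bears on this change, and the one step shown is unreadable. No step beyond the scatter is therefore expected in this assay. Compound 3 is expected near 25000 nM, between 10000 nM and 60000 nM, an estimated step that the limit leaves unreadable from compound 2 to compound 3.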

Compound 3, half-maximal effective concentration: > 26000 nM
Compound 3: no number, only a limit; the forecaster's own chance of this, stated with the estimate: 75%; middle value at least 1.0-fold (0.01 log units) away from the limit.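

Compound 3 gives > 26000 nM, a limit, and compound 2 also stands only at a limit, so no step can be read between them. The compounds shown leave open what concentration of any of them would produce an effect in this assay.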